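Three Limits and a Pyridine Amide Still Unmeasured

The source may report more compounds than this note shows. Statements on the series, on what has been measured and on what is new or still open speak of the compounds shown alone.

Measured compounds in an ADME assay on HepG2 cells (Homo sapiens) for cytotoxicity; a lower number here means that less compound is needed, a higher number that more compound is needed for the effect
compound 1 `Cc1ccc(S(=O)(=O)N[C@@H](CC(=O)NC(C)(C)C)C(=O)NCCNC(=O)c2cccc(O)c2)cc1` gives > 11000 nM as a limit
compound 2 `Cc1ccc(S(=O)(=O)N[C@@H](CC(=O)NC(C)(C)C)C(=O)NCCNC(=O)c2cccc(F)c2)cc1` gives > 11000 nM as a limit
compound 3 `Cc1ccc(S(=O)(=O)N[C@@H](CC(=O)NC(C)(C)C)C(=O)NCCNS(=O)(=O)c2ccccc2)cc1` gives > 11000 nM as a limit

Each of these three results is a limit of the assay and not a number. Compound 3 therefore has no number of its own and stands with the other two at the limit of > 11000 nM in this assay, at which 3 of the 3 values shown sit, in this series.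

Compound 4 `Cc1ccc(S(=O)(=O)N[C@@H](CC(=O)NC(C)(C)C)C(=O)NCCNC(=O)c2cc(C)ccn2)cc1` has not yet been measured. It carries (4-methylpyridin-2-yl)carbonyl in place of phenylsulfonyl on an amine nitrogen, and (4-methylpyridin-2-yl)carbonyl in place of phenylsulfonyl on an amine nitrogen gives the full count of that swap.

Within the data shown here, three measured steps bear on this change, namely a step that the two limits leave unreadable from compound 1 to compound 3 and a step that the two limits leave unreadable from compound 2 to compound 3 and also a step that the two limits leave unreadable from compound 1 to compound 2 in the same series. None has a readable size. Among the measured compounds shown here, still, the compounds with a substituted phenylcarbonyl group and the one with phenylsulfonyl on that nitrogen all sit at the same limit, and no measured compound goes against this. The expectation in this assay is therefore no step beyond the scatter, in either direction, and a further limit is the most likely report.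

The estimate amounts to a step that the limit leaves unreadable from compound 3 to compound 4 as the expected change. For compound 4 the estimated value is 14000 nM with an expected range from 9000 nM to 30000 nM as its span.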

Compound 4, half-maximal effective concentration: > 11000 nM
Compound 4 gave a limit, no number; the forecaster's own chance of this, stated with the estimate: 85%; the middle value lies beyond the limit too.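

In this assay compound 4 gives > 11000 nM, which is a limit of the assay and not a number. Its steps from compound 1, compound 2 and compound 3 therefore cannot be read, and all four compounds share one result: the limit of > 11000 nM in this assay, at which 4 of the 4 values shown sit.

The compounds shown leave open what concentration any of them needs for the effect, and whether any of these swaps changes it.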